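A few compounds are considered here, and "the series" means these few. Any claim that something is new, unique, unknown or untested is made for them only; others in the source may bear on it.

Of the compounds shown here, three built on one shared core have been tested in an ADME assay on A549 cells (Homo sapiens) for cytotoxicity, read by resazurin assay, with a stated time of 48 h; a higher number here means that more compound is tolerated, a lower number that less compound is tolerated. Compound 1 `CCCNc1ccc(NC(=O)c2cc(Cl)ccc2O)c(Cl)c1` gives 22500 nM. Compound 2 `O=C(Nc1ccc(NC2CCCCC2)cc1Cl)c1cc(Cl)ccc1O` gives 68300 nM, the highest of the three numbers. Compound 3 `O=C(Nc1ccc(NCc2ccccc2)cc1Cl)c1cc(Cl)ccc1O` gives 19700 nM. Two of the steps among them lie beyond the scatter: a 3.0-fold higher number from compound 1 to compound 2 (0.48 log units; beyond the scatter) and a 3.5-fold lower number from compound 2 to compound 3 (0.54 log units; beyond the scatter), each described as modest. The third step is within the scatter: a 1.1-fold lower number from compound 1 to compound 3 (0.06 log units; within the scatter).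

Compound 4 `CC(CCO)Nc1ccc(NC(=O)c2cc(Cl)ccc2O)c(Cl)c1` has not yet been measured in this assay. It differs from compound 2 in one place: 3-hydroxy-1-methylpropyl in place of cyclohexyl on a nitrogen on an aromatic ring. Both measured steps that touch compound 2 bear on this change, since in each of them the cyclohexyl group on the nitrogen on the aromatic ring is exchanged against another group, and in each the number on the cyclohexyl side is the higher one. The group entering in compound 4 has no ring, like the propyl of compound 1, so the expected step is a modest fall, a 3.1-fold lower number from compound 2 to compound 4 (0.49 log units; beyond the scatter), of roughly the size seen when propyl was present. Compound 4 is therefore expected to give about 22000 nM, with a range from 8000 nM to 55000 nM.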

Compound 4, half-maximal cytotoxic concentration: 200000 nM
Estimate against measurement, compound 4: 9.1-fold (0.96 log units) below, outside the stated range (above it).
By their numbers in this assay, from the lowest: compounds 3 and 1 (each within the scatter of the next); then compound 2; then compound 4.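

In this assay, the group on a nitrogen on an aromatic ring proves able to move the number further than the first three compounds suggested: cyclohexyl no longer marks the top of the series, as 3-hydroxy-1-methylpropyl in its place gives a 2.9-fold higher number from compound 2 to compound 4 (0.47 log units; beyond the scatter). Against the other two groups the same entering group gives a 10-fold higher number from compound 3 to compound 4 (1.01 log units; beyond the scatter) and an 8.9-fold higher number from compound 1 to compound 4 (0.95 log units; beyond the scatter), so having no ring does not by itself set the number: propyl and 3-hydroxy-1-methylpropyl both lack a ring, yet compound 1 and compound 4 stand far apart. Nothing shown here offers a measured account of these steps.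

The compounds shown leave open whether the rise follows the hydroxyl or the methyl branch of the entering group, and a plain 3-hydroxypropyl chain or a butyl chain would separate the two. They also leave open whether a methoxy group, an amine or a carboxylic acid in place of the hydroxyl would keep the number as high as in compound 4.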